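A Second Aryl Swap on the Shared Core

The source may hold more compounds than are shown below. What is called first, only, known or untested is meant among the compounds shown, and "the series" means these compounds.

Compound 2 `Cc1nc(C)n(CC(=O)N2CCN(c3sc(C(F)(F)F)nc3-c3cnc(C4CC4)nc3)C[C@H]2C)n1` gives 3.5 nM in a functional assay on CHO-K1 cells for antagonist activity at C-X-C chemokine receptor type 3 (Homo sapiens), read by FLIPR, with a stated time of 10 min (a higher number here means a weaker inhibitor, a lower number a stronger inhibitor), the lower of the two numbers shown, yet within the scatter of compound 1 `Cc1nc(C)n(CC(=O)N2CCN(c3sc(C(F)(F)F)nc3-c3cnc(OC4CCC4)nc3)C[C@H]2C)n1`, which gives 4 nM. Compound 3 `COc1ccc(-c2nc(C(F)(F)F)sc2N2CCN(C(=O)Cn3nc(C)nc3C)[C@H](C)C2)cn1` differs from compound 2 by 6-methoxypyridin-3-yl in place of 2-cyclopropylpyrimidin-5-yl on an aromatic carbon. Among the compounds with values here, the only measured step, a 1.1-fold lower number from compound 1 to compound 2 (0.06 log units; within the scatter), altered a substituent on the same aromatic partner and stayed within the scatter. Within the data shown here, no measured step exchanges that ring itself, so its bearing is indirect. For compound 3 a modest step is expected, a 1.7-fold higher number from compound 2 to compound 3 (0.23 log units; within the scatter), if anything toward a higher number. Compound 3 is therefore estimated at 6 nM, within 2 nM to 20 nM.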

Compound 3, half-maximal inhibitory concentration: 18 nM
Compound 3: the middle estimate sits 3.0-fold (0.48 log units) below what was measured; measured number inside the range.
By their numbers in this assay, from the lowest: compounds 2 and 1 (each within the scatter of the next); then compound 3.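

Exchanging the aromatic ring on this carbon moved the number where changing the group on the pyrimidine had not: the values rose with a 5.1-fold higher number from compound 2 to compound 3 (0.71 log units; beyond the scatter) and with a 4.5-fold higher number from compound 1 to compound 3 (0.65 log units; beyond the scatter) in this assay and both steps lie beyond the scatter. Nothing measured here gives a reason for this.

6-Methoxypyridin-3-yl differs from both pyrimidines in its ring and in its substituent, so the compounds shown leave open which of the two carries the step. A 2-methoxypyrimidin-5-yl or a 6-cyclopropylpyridin-3-yl group on the same carbon would separate them.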